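The compounds below may be only part of what the source reports. "The series", "measured", "known", "first", "only" and "open" are said of these compounds alone.

Measured compounds:
compound 1, `COCCNC(=O)[C@H]1C[C@H](Nc2ncc3c(Br)nn(-c4ccc5ncccc5c4)c3n2)C1`: 86 nM
compound 2, `COCCNC(=O)[C@@H]1CC[C@H](Nc2ncc3c(Br)nn(-c4ccc5ncccc5c4)c3n2)C1`: "nd" (no result reported)
compound 3, `COCCC(=O)N[C@@H]1CC[C@@H](Nc2ncc3c(Br)nn(-c4ccc5ncccc5c4)c3n2)C1`: 159 nM

Three compounds with a shared core have been examined in an assay on SK-OV-3 cells for inhibition of eIF-2-alpha kinase GCN2 (Homo sapiens); on this read-out higher numbers stand for weaker inhibition and lower numbers for stronger inhibition. Compound 1 `COCCNC(=O)[C@H]1C[C@H](Nc2ncc3c(Br)nn(-c4ccc5ncccc5c4)c3n2)C1` gives 86 nM in this assay. Compound 2 `COCCNC(=O)[C@@H]1CC[C@H](Nc2ncc3c(Br)nn(-c4ccc5ncccc5c4)c3n2)C1` has no result reported. Compound 3 `COCCC(=O)N[C@@H]1CC[C@@H](Nc2ncc3c(Br)nn(-c4ccc5ncccc5c4)c3n2)C1`, which carries the carbonyl group on the amine nitrogen rather than in the ring substituent, gives 159 nM in this assay. The two numbers for compound 1 and compound 3 lie within the usual scatter of each other, so neither can be called the stronger inhibitor on this evidence.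

Compound 4 `COCCS(=O)(=O)N[C@@H]1CC[C@@H](Nc2ncc3c(Br)nn(-c4ccc5ncccc5c4)c3n2)C1` follows from compound 3 by a single change: (2-methoxyethyl)sulfonyl in place of (2-methoxyethyl)carbonyl on an amine nitrogen. Within the data shown here, no measured pair in this set shows the effect of such an exchange, so the expectation rests on the closeness of the three measured compounds alone. The step from compound 3 to compound 4 is expected to be small, a 1.3-fold higher number from compound 3 to compound 4 (0.10 log units; within the scatter), not beyond the scatter and if anything towards a weaker number. Compound 4 is therefore estimated at 200 nM in this assay, with a range from 80 nM to 500 nM.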

Compound 4, half-maximal inhibitory concentration: 262 nM
Compound 4: middle estimate off by 1.3-fold (0.12 log units), on the low side; the range from low to high includes it.
By their numbers in this assay, from the lowest: compounds 1, 3 and 4 (each within the scatter of the next, the first and the last beyond it).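

In this assay, among these compounds, the pair of compound 3 and compound 4 is the first in this set to differ in one place only, and it gives a direct reading of this position: (2-methoxyethyl)sulfonyl in place of (2-methoxyethyl)carbonyl on an amine nitrogen gives a 1.6-fold higher number from compound 3 to compound 4 (0.22 log units; within the scatter). The exchange adds one heavy atom, one hydrogen-bond acceptor and a second double bond outside aromatic rings, and swaps a carbon for a sulfur, yet this read-out does not separate the two compounds, so on this evidence the two linking groups are interchangeable here. Nothing available explains why the read-out responds so little to this exchange.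

The compounds shown leave open whether the position stays this undemanding with a different chain on the same linking groups, such as a longer chain, or one ending in an amine or a carboxylic acid in place of the methoxy end. They also leave open whether a urea on that amine nitrogen would fall as close to compound 3 as the sulfonyl group does.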